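A Carboxylic Acid Replaces the Side Chain of Compound 3

A few compounds are considered here, and "the series" means these few. Any claim that something is new, unique, unknown or untested is made for them only; others in the source may bear on it.

In a functional assay on PC-3 cells (Homo sapiens) for antiproliferative activity, read by MTT assay, with a stated time of 24 h (on this read-out lower numbers stand for stronger inhibition and higher numbers for weaker inhibition), compound 1 (`CCn1c(C(=O)N[C@@H](CC(=O)OC)C(=O)OC)ccc1C(CC)(CC)c1ccc(OCS(=O)(=O)c2ccccc2)c(C)c1`) gives 6490 nM, while compound 3 (`CCn1c(C(=O)N[C@@H](CO)CCCO)ccc1C(CC)(CC)c1ccc(OCS(=O)(=O)c2ccccc2)c(C)c1`) gives 13400 nM, the higher of the two exact numbers. Compound 2 (`CCn1c(C(=O)NCCNC(=O)OC(C)(C)C)ccc1C(CC)(CC)c1ccc(OCS(=O)(=O)c2ccccc2)c(C)c1`) reads > 50000 nM, which is a limit and not an exact number.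

Compound 4 (`CCn1c(C(=O)N[C@H](C(=O)O)C(C)C)ccc1C(CC)(CC)c1ccc(OCS(=O)(=O)c2ccccc2)c(C)c1`) carries 1-carboxy-2-methylpropyl on the amide-type nitrogen in place of the group in compound 3: a group of 7 heavy atoms (5 carbon, 2 oxygen; no ring) in place of a group of 7 heavy atoms (5 carbon, 2 oxygen; no ring), on an amide-type nitrogen. All three measured steps changed this same place. The first, a 2.1-fold higher number from compound 1 to compound 3 (0.31 log units; beyond the scatter), was modest, whereas an at least 3.7-fold lower number from compound 2 to compound 3 (0.57 log units; beyond the scatter) and an at least 7.7-fold higher number from compound 1 to compound 2 (0.88 log units; beyond the scatter) are open-ended. Each of these two involves the limit. For the measured compounds named here, none of the measured compounds carries a free carboxy group, so no step tests this change directly. Given the modest size of a 2.1-fold higher number from compound 1 to compound 3 (0.31 log units; beyond the scatter), only a small upward move is expected in this assay. The estimated change is a 1.5-fold higher number from compound 3 to compound 4 (0.17 log units; within the scatter), and this expected change may stay within the scatter. For compound 4 the estimated value is 20000 nM, with an expected range of 7000 nM to 50000 nM.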

Compound 4, half-maximal inhibitory concentration: 3650 nM
Compound 4: the middle estimate sits 5.5-fold (0.74 log units) above what was measured; measured number below the stated range.
By their numbers in this assay, from the lowest: compounds 4 and 1 (each within the scatter of the next); then compound 3. At a limit, above all of these: compound 2.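

In this assay, for the compounds shown here, 1-carboxy-2-methylpropyl on the amide-type nitrogen brings a 3.7-fold lower number from compound 3 to compound 4 (0.56 log units; beyond the scatter) and so shows that a free carboxy group at this place can go with a lower number, a change no earlier step had tested. Set against the 1,2-bis(methoxycarbonyl)ethyl group, it brings a 1.8-fold lower number from compound 1 to compound 4 (0.25 log units; within the scatter) and this step stays within the scatter, so compound 1 and compound 4 cannot be ordered. Compound 2 reads only a limit, which leaves an at least 13-fold lower number from compound 2 to compound 4 (1.13 log units; beyond the scatter) open-ended: the limit of > 50000 nM in this assay, at which 1 of the 4 values shown sits.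

Only one carboxylic acid is shown, so the step from compound 3 cannot separate the carboxy group from the rest of 1-carboxy-2-methylpropyl. From the compounds shown here alone, how the methyl ester of this group, an amine or a longer chain ending in the acid would read at this place remains open.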